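The source may hold more compounds than are shown below. What is called first, only, known or untested is meant among the compounds shown, and "the series" means these compounds.

This series shares one core and differs only in the group attached to an amine nitrogen. In a functional assay on HEL cells (Homo sapiens) for cytotoxicity, read by microscopy (on this read-out higher numbers stand for lower toxicity in this test and lower numbers for higher toxicity in this test), compound 1 `Cc1cn([C@@H]2O[C@H](CO[Si](C)(C)C(C)(C)C)[C@@]3(OS(=O)(=O)C=C3NCC(N)=O)[C@H]2O[Si](C)(C)C(C)(C)C)c(=O)n(C)c1=O` gives 16000 nM. Compound 2 `Cc1cn([C@@H]2O[C@H](CO[Si](C)(C)C(C)(C)C)[C@@]3(OS(=O)(=O)C=C3NCC(=O)C(=O)N3CCC3)[C@H]2O[Si](C)(C)C(C)(C)C)c(=O)n(C)c1=O` gives 65000 nM, the second highest of the three numbers, and compound 3 `COC(=O)CC(=O)NC1=CS(=O)(=O)O[C@@]12[C@@H](CO[Si](C)(C)C(C)(C)C)O[C@@H](n1cc(C)c(=O)n(C)c1=O)[C@@H]2O[Si](C)(C)C(C)(C)C` gives 400000 nM. Compound 4 `Cc1cn([C@@H]2O[C@H](CO[Si](C)(C)C(C)(C)C)[C@@]3(OS(=O)(=O)C=C3NC(=O)NC(=O)c3ccccc3)[C@H]2O[Si](C)(C)C(C)(C)C)c(=O)n(C)c1=O` has not been measured; its difference from compound 2 is benzoylcarbamoyl in place of (((azetidin-1-yl)carbonyl)carbonyl)methyl on an amine nitrogen. Two measured steps involve compound 2: a 4.1-fold higher number from compound 1 to compound 2 (0.61 log units; beyond the scatter) and a 6.2-fold higher number from compound 2 to compound 3 (0.79 log units; beyond the scatter), both modest, and together they show that changing this group moves the number beyond the scatter in either direction. Benzoylcarbamoyl resembles none of the measured groups, so no direction stands out, and a modest step of uncertain sign is the reasonable expectation. Compound 4 is therefore estimated at 80000 nM, within a range of 15000 nM to 350000 nM, meaning a 1.2-fold higher number from compound 2 to compound 4 (0.09 log units; within the scatter) is expected.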

Compound 4, minimum cytotoxic concentration: >= 80000 nM
Compound 4: only a limit was reported (the forecaster's own chance of this, stated with the estimate: 20%); the middle value lies on the limit itself.
By their numbers in this assay, from the lowest: compound 1; then compound 2; then compound 3.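

In this assay (this assay) compound 4 is reported only as a limit (>= 80000 nM). Even so, benzoylcarbamoyl on the amine nitrogen gives a clear step (an at least 5.0-fold higher number from compound 1 to compound 4 (0.69 log units; beyond the scatter)), so a group with a six-membered aromatic ring can sit here and stay clear of the lowest number in the series. The other comparisons settle little: one floor stays within the scatter (an at least 1.2-fold higher number from compound 2 to compound 4 (0.09 log units; that floor lies within the scatter)), and the step involving compound 3 cannot be read.

From the compounds shown here alone, the true number for compound 4 remains open. So does whether a plain benzoyl group on this nitrogen, or a urea carrying a short alkyl chain, would behave the same way.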